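A few compounds are considered here, and "the series" means these few. Any claim that something is new, unique, unknown or untested is made for them only; others in the source may bear on it.

In an assay on membranes from CHO cells for displacement of a labelled ligand from adenosine receptor A1 (Homo sapiens), read by scintillation counting, with a stated time of 60 min, tested at 1 uM (a higher number here means more inhibition at the concentration tested (going by the name of the read-out), a lower number less inhibition), compound 1 `CCCOC(=O)C1=C(C)NC(=S)NC1c1ccsc1` gives 5%, and compound 2 `CC1=C(C(=O)OCC(C)C)C(c2ccsc2)NC(=S)N1` gives 8%. The two structures differ by methyl in place of hydrogen on a saturated chain carbon bound to two saturated chain carbons, and the values show a number 3 percentage points higher from compound 1 to compound 2 (within the scatter). Compound 3 `CCCOC(=O)C1=C(C)N(C)C(=O)NC1c1cccs1` gives 9% in this assay; the difference between its core and the core of compound 1 is not broken down here, and its values against compound 1 and compound 2 both lie within the usual scatter, so no order among the three can be read from them. All three sit at a low level of inhibition at the single concentration tested.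

Compound 4 `CC1=C(C(=O)OCC(C)C)C(c2cccs2)NC(=O)N1C` has not yet been measured in this assay. It differs from compound 3 by methyl in place of hydrogen on a saturated chain carbon bound to two saturated chain carbons, which is the same change that separates compound 1 from compound 2. Because that earlier step amounted to a number 3 percentage points higher from compound 1 to compound 2 (within the scatter), the expected step here is a number 2 percentage points higher from compound 3 to compound 4 (within the scatter), a move that would stay within the scatter. Compound 4 is therefore estimated to give 11% in this assay, expected to fall between 0% and 22%.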

Compound 4, a percentage reported as inhibition, at one concentration (the size of the read-out at that concentration, not a potency): 9%
Estimate against measurement, compound 4: 2 percentage points above; low and high end bracket the measured number.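

Going from propoxy to isobutoxy on the core of compound 3, this assay gives no change at the digits printed from compound 3 to compound 4 (within the scatter), at a place described as a saturated chain carbon bound to two saturated chain carbons. Set beside the earlier step, the same change behaves alike on the two cores: the same change on two cores in this assay, a number 3 percentage points higher (within the scatter) from compound 1 to compound 2 and no change at the digits printed (within the scatter) from compound 3 to compound 4, 3 percentage points apart, within the scatter of two such steps. This shows that, in these two pairs, the methyl carried from one core to the other leaves the inhibition at the same low level within the scatter, but it does not show that the change is without effect in general, since two pairs at this low level, read at a single concentration, cannot reveal a step that would appear only at higher inhibition.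

The compounds shown leave open whether a longer chain on the ester oxygen, or a carboxylic acid or an amine in place of that ester chain, would raise the inhibition on either core. For the compounds shown here, they also leave open how the differences between the two cores act one at a time, as no pair here separates them.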